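A Fluorophenyl Group Replaces Cycloheptyl on an Amine Nitrogen in a Ring

The source may report more compounds than this note shows. Statements on the series, on what has been measured and on what is new or still open speak of the compounds shown alone.

Compound 2 `Nc1scc(CN2CCN(C3CCCCCC3)CC2)c1C(=O)c1ccc(Cl)cc1` carries a cycloheptyl group on an amine nitrogen in a ring. In an assay on CHO cells for displacement of a labelled ligand from adenosine receptor A1 (Homo sapiens), read by scintillation counting, with a stated time of 120 min, tested at 10 uM (on this read-out higher numbers stand for more inhibition at the one concentration tested (going by the name of the read-out) and lower numbers for less inhibition), compound 2 gives 0%. Compound 1 `Nc1scc(CN2CCN(c3cc(Cl)cc(Cl)c3)CC2)c1C(=O)c1ccc(Cl)cc1` differs only by bearing 3,5-dichlorophenyl at that place, and in this assay compound 1 gives 1%; the step of a number 1 percentage points lower from compound 1 to compound 2 (within the scatter) leaves the two compounds indistinguishable, both showing almost no displacement of the labelled ligand. Compound 3 `Nc1scc(CN2CCN(c3ccccc3F)CC2)c1C(=O)c1ccc(Cl)cc1` has not yet been measured. Its change from compound 2 is 2-fluorophenyl in place of cycloheptyl on an amine nitrogen in a ring. Among the measured compounds shown here, the one measured step that bears on this, a number 1 percentage points lower from compound 1 to compound 2 (within the scatter), swapped an aromatic ring for a non-aromatic one at the same place without moving the read-out, so another swap at this place is expected to leave the number about where compound 2 stands. Compound 3 is therefore estimated to give 2%, with a range of -8% to 14%, which means an expected step of a number 2 percentage points higher from compound 2 to compound 3 (within the scatter).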

Compound 3, a percentage reported as inhibition, at one concentration (the size of the read-out at that concentration, not a potency): 4%
Beside the measured number, compound 3's estimate is 2 percentage points below it, and the stated range covers the measured number.
By their numbers in this assay, from the lowest: compounds 2, 1 and 3 (each within the scatter of the next).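

Putting 2-fluorophenyl on the amine nitrogen in the ring gives a number 4 percentage points higher from compound 2 to compound 3 (within the scatter) in this assay, and replacing 3,5-dichlorophenyl with it gives a number 3 percentage points higher from compound 1 to compound 3 (within the scatter). Three different groups at this place, one non-aromatic and two aromatic with different halogens, therefore cannot be told apart, and all three numbers lie close to zero at the one concentration tested, so this read-out offers no ranking among them. No supporting measurement is available to explain this result.

As far as these compounds go, it remains open whether a benzyl group, a pyridine ring or a phenyl ring carrying a carboxylic acid at this place would give a clearly higher number. From the compounds shown here alone, the rest of the molecule is the same in all three compounds, so the effect of changing any other part also remains open.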